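Swapping chloro for fluoro: expected effect on cell toxicity

The compounds below may be only part of what the source reports. "The series", "measured", "known", "first", "only" and "open" are said of these compounds alone.

Measured compounds:
Compound 1, `CONC(=S)N/N=C1\C(=O)N(CN2CCN(c3ccc(Cl)cc3)CC2)c2ccc(Cl)cc21`: 229000 nM
Compound 2, `CCN(CC)CN1C(=O)/C(=N\NC(=S)NO)c2cc(Cl)ccc21`: 562000 nM
Compound 3, `CCN(CC)CN1C(=O)/C(=N\NC(=S)NO)c2cc(F)ccc21`: 521000 nM

These three compounds were tested in an ADME assay on MT4 cells (Homo sapiens) for cytotoxicity, read by spectrophotometry, with a stated time of 5 days; on this read-out lower numbers stand for higher toxicity in this test and higher numbers for lower toxicity in this test. Compound 1 gives the lowest of the three numbers; the difference between its core and that of compound 2 is not broken down here. Compound 2 and compound 3 share a core and differ in one place, (fluoro in place of chloro on an aromatic carbon); that change gave a 1.1-fold lower number from compound 2 to compound 3 (0.03 log units; within the scatter).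

Compound 4, `CONC(=S)N/N=C1\C(=O)N(CN2CCN(c3ccc(Cl)cc3)CC2)c2ccc(F)cc21`, has not yet been measured in this assay. It is made from compound 1 by the same change, (fluoro in place of chloro on an aromatic carbon). Because the step of a 1.1-fold lower number from compound 2 to compound 3 (0.03 log units; within the scatter) was small, compound 4 is expected to stay close to compound 1, with an estimated step of a 1.1-fold lower number from compound 1 to compound 4 (0.04 log units; within the scatter). The estimated value for compound 4 is 210000 nM, expected to lie between 100000 nM and 450000 nM.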

Compound 4, half-maximal cytotoxic concentration: 347000 nM
Estimate against measurement, compound 4: 1.7-fold (0.22 log units) below; measured number inside the range.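

In this assay the swap of chloro for fluoro gave a 1.5-fold higher number from compound 1 to compound 4 (0.18 log units; within the scatter) and so stayed within the usual scatter on the core of compound 1, as it did on the core of compound 2. The two cores show no real difference in how they respond to this change: the same change on two cores in this assay, a 1.1-fold lower number (0.03 log units; within the scatter) from compound 2 to compound 3 and a 1.5-fold higher number (0.18 log units; within the scatter) from compound 1 to compound 4, 1.6-fold (0.21 log units) apart, within the scatter of two such steps. This suggests the swap carries across these two cores with little effect on this read-out, but two pairs cannot show that it would hold on any other core or in any other test.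

As far as these compounds go, only chloro and fluoro appear on this aromatic carbon, so the outcome with bromo, methoxy or a nitrile there remains open.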